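Moving the methoxycarbonyl group: from compound 3 to compound 4

This account rests on a few compounds, and the source may have more. Where it says the series, first, only, none or still open, it means among the compounds named here.

- compound 1 `CC1(C)Oc2ccc(C#N)cc2[C@@H](/N=C(\NC#N)Nc2ccc(Cl)cc2)[C@@H]1O`: 1800 nM
- compound 2 `CC1(C)Oc2ccc(C#N)cc2[C@@H](/N=C(\NC#N)Nc2cccc([N+](=O)[O-])c2)[C@@H]1O`: 670 nM
- compound 3 `COC(=O)c1cccc(N/C(=N/[C@@H]2c3cc(C#N)ccc3OC(C)(C)[C@H]2O)NC#N)c1`: 4100 nM

In a functional assay (aorta) with Rattus norvegicus as the target (a lower number here means a stronger inhibitor, a higher number a weaker inhibitor), compound 3 stands highest of the three, at 4100 nM. Compound 4 `COC(=O)c1ccc(N/C(=N/[C@@H]2c3cc(C#N)ccc3OC(C)(C)[C@H]2O)NC#N)cc1` is unmeasured and differs by 4-(methoxycarbonyl)phenyl in place of 3-(methoxycarbonyl)phenyl on an amine nitrogen. For the measured compounds named here, no measured step makes this exact change. The closest evidence is replacement of the group on that nitrogen: a 2.3-fold higher number from compound 1 to compound 3 (0.36 log units; beyond the scatter), and a 6.1-fold higher number from compound 2 to compound 3 (0.79 log units; beyond the scatter), both modest. Compound 1, with 4-chlorophenyl on that nitrogen, gives 1800 nM, which points weakly towards a lower number. A modest step is therefore expected in this assay: a 1.6-fold lower number from compound 3 to compound 4 (0.21 log units; within the scatter). Compound 4 is estimated at 2500 nM, with an expected range of 900 nM to 7000 nM.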

Compound 4, half-maximal inhibitory concentration: 18400 nM
For compound 4 the middle estimate is 7.4-fold (0.87 log units) below the measured one; measured number above the stated range.
By their numbers in this assay, from the lowest: compound 2; then compound 1; then compound 3; then compound 4.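

In this assay, the location of the methoxycarbonyl group on the phenyl ring matters, not just its presence: 4-(methoxycarbonyl)phenyl in place of 3-(methoxycarbonyl)phenyl gives a clear loss (a 4.5-fold higher number from compound 3 to compound 4 (0.65 log units; beyond the scatter)) with identical counted features. The same group also separates compound 4 from the other two by large steps (a 10-fold higher number from compound 1 to compound 4 (1.01 log units; beyond the scatter); a 27-fold higher number from compound 2 to compound 4 (1.44 log units; beyond the scatter)), making compound 4 the weakest of the four. Nothing available explains this loss.

As far as these compounds go, whether a carboxylic acid or a primary amide would show the same dependence on location stays open. So does the behaviour of chloro and nitro, each seen on the phenyl ring in one location only.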